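From 2,3-dimethylbenzyl to 2,5-dichlorobenzyl

The source may report more compounds than this note shows. Statements on the series, on what has been measured and on what is new or still open speak of the compounds shown alone.

In a functional assay on Jurkat cells (Homo sapiens) (a higher number here means a weaker inhibitor, a lower number a stronger inhibitor), compound 1 `C[C@H](NC(=O)C(=O)Nc1cccnc1N(C)C)C(=O)N[C@@H](CC(=O)O)C(=O)COc1c(F)c(F)cc(F)c1F` gives 27 nM, compound 2 `Cc1ccccc1CNC(=O)C(=O)N[C@@H](C)C(=O)N[C@@H](CC(=O)O)C(=O)COc1c(F)c(F)cc(F)c1F` gives 52 nM and compound 3 `Cc1cccc(CNC(=O)C(=O)N[C@@H](C)C(=O)N[C@@H](CC(=O)O)C(=O)COc2c(F)c(F)cc(F)c2F)c1C` gives 102 nM. Compound 3 therefore cannot be told apart from compound 2, but it is a weaker inhibitor than compound 1, with a 3.8-fold higher number from compound 1 to compound 3 (0.58 log units; beyond the scatter).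

Compound 4 `C[C@H](NC(=O)C(=O)NCc1cc(Cl)ccc1Cl)C(=O)N[C@@H](CC(=O)O)C(=O)COc1c(F)c(F)cc(F)c1F` keeps the shared core and differs from compound 3 in one group: 2,5-dichlorophenyl in place of 2,3-dimethylphenyl on a saturated chain carbon bound to an amide-type nitrogen. Here, 2,5-dichlorophenyl takes the place of 2,3-dimethylphenyl on a saturated chain carbon bound to an amide-type nitrogen.

The closest guide is the added methyl on an aromatic carbon, which gave a 2.0-fold higher number from compound 2 to compound 3 (0.29 log units; within the scatter). The exchange of the whole group gave a 1.9-fold higher number from compound 1 to compound 2 (0.28 log units; within the scatter). For the measured compounds named here, none of the measured compounds carries chlorine, so the data offer no direct precedent. No shift beyond the scatter is therefore expected in this assay.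

The estimated change is a 1.7-fold lower number from compound 3 to compound 4 (0.23 log units; within the scatter). The expected value for compound 4 is 60 nM, with an estimated range of 20 nM to 180 nM.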

Compound 4, half-maximal inhibitory concentration: 4.3 nM
For compound 4 the middle estimate is 14-fold (1.14 log units) above the measured one; the measured number lies below the stated range.
By their numbers in this assay, from the lowest: compound 4; then compounds 1, 2 and 3 (each within the scatter of the next, the first and the last beyond it).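

In this assay, the group on the saturated chain carbon bound to an amide-type nitrogen matters far more than the earlier methyl step suggested: 2,5-dichlorophenyl in place of 2,3-dimethylphenyl gives a large shift (a 24-fold lower number from compound 3 to compound 4 (1.38 log units; beyond the scatter)), although both groups count the same number of heavy atoms. The shift is also large against the 2-methylphenyl group (a 12-fold lower number from compound 2 to compound 4 (1.08 log units; beyond the scatter)), so it does not depend on the 2,3-dimethylphenyl group alone. The 2,5-dichlorobenzyl group also beats the 2-(dimethylamino)pyridin-3-yl group on the same nitrogen (a 6.3-fold lower number from compound 1 to compound 4 (0.80 log units; beyond the scatter)), which makes compound 4 the strongest inhibitor of the four.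

No measurement here accounts for the gain. On these data alone, whether a single chlorine would be enough, or whether bromine or trifluoromethyl on the ring would do as well, remains open.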